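Swapping the carbonyl arm on the shared core

The source may hold more compounds than are shown below. What is called first, only, known or untested is meant among the compounds shown, and "the series" means these compounds.

Three compounds of the series have numbers in an ADME assay on HEK293 cells (Homo sapiens) for antiproliferative activity, read by MTT assay, with a stated time of 24 h; a higher number here means a weaker inhibitor, a lower number a stronger inhibitor. Compound 1 `COc1cc(-c2cc(/C=C/C(=O)c3ccc(C)c(C)c3)nc3cc(-c4ccccc4)nn23)cc(OC)c1OC` gives 72500 nM, compound 3 `COc1cc(-c2cc(/C=C/C(=O)c3ccc(C)cc3)nc3cc(-c4ccccc4)nn23)cc(OC)c1OC` gives 50400 nM, and compound 2 `COc1ccc(C(=O)/C=C/c2cc(-c3ccc(OC)c(OC)c3)n3nc(-c4ccccc4)cc3n2)cc1` gives 40000 nM, the lowest of the three, though its gaps to compound 3 and to compound 1 both lie within the scatter. Among the compounds with values here, the one measured step, a 1.4-fold lower number from compound 1 to compound 3 (0.16 log units; within the scatter), also stayed within the scatter. Compound 4 `COc1ccc(-c2cc(C(=O)/C=C/c3ccc(Cl)cc3)nc3cc(-c4ccccc4)nn23)cc1OC` differs from compound 2 by (2-(4-chlorophenyl)ethenyl)carbonyl in place of 2-((4-methoxyphenyl)carbonyl)ethenyl on an aromatic carbon. Within the data shown here, no measured step touches this part of the molecule, so nothing measured speaks for or against a shift, and the only step seen was small. Compound 4 is therefore expected to sit near the same level, with a step of no change at the digits printed from compound 2 to compound 4 (within the scatter) and an estimate of 40000 nM within 15000 nM to 100000 nM in this assay.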

Compound 4, half-maximal inhibitory concentration: 39100 nM
Compound 4: the middle estimate sits 1.0-fold (0.01 log units) above what was measured; measured number inside the range.
By their numbers in this assay, from the lowest: compounds 4, 2, 3 and 1 (each within the scatter of the next).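

In this assay, the arm on the aromatic carbon next to the ring nitrogen tolerates a full exchange: (2-(4-chlorophenyl)ethenyl)carbonyl in place of 2-((4-methoxyphenyl)carbonyl)ethenyl gives a 1.0-fold lower number from compound 2 to compound 4 (0.01 log units; within the scatter). This swap alters the carbonyl's place in the arm, the group on the arm's aromatic ring and the count of hydrogen-bond acceptors together, yet the two compounds cannot be told apart. No supporting data bear on this result. As far as these compounds go, the separate contributions of the carbonyl's place and the chlorine remain open. So does the reading with an amine or a carboxylic acid on the arm's aromatic ring.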